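A few compounds are considered here, and "the series" means these few. Any claim that something is new, unique, unknown or untested is made for them only; others in the source may bear on it.

Of the compounds shown here, two have been measured in an assay on cells for displacement of a labelled ligand from adenosine receptor A1 (Homo sapiens), read by scintillation counting and radioligand binding, with a stated time of 60 min, tested at 10 uM; on this read-out lower numbers stand for less inhibition and higher numbers for more inhibition at the one concentration tested (going by the name of the read-out). Compound 1 `Cn1cnc2c(N3CCCCC3)nc(-c3cccc(O)c3O)nc21` gives 17.2% and compound 2 `Cn1cnc2c(N3CCCCC3)nc(-c3cccc(O)c3)nc21` gives 78.5%. Among the measured compounds shown here, the one change between them is hydrogen in place of hydroxy on an aromatic carbon, and the step is a number 61.3 percentage points higher from compound 1 to compound 2 (beyond the scatter). For the measured compounds named here, compound 2 therefore stands highest of the two numbers, with compound 1 as its only neighbour, well beyond the scatter below it.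

Compound 3 `Cn1cnc2c(N3CCCCC3)nc(-c3ccccc3Cl)nc21` is not yet measured in this assay. It differs from compound 2 by 2-chlorophenyl in place of 3-hydroxyphenyl on an aromatic carbon. Going by the values given here, only one measured step bears on this change, a number 61.3 percentage points higher from compound 1 to compound 2 (beyond the scatter), which shows that a hydroxy change on that ring can move the read-out by a large amount; no measured pair exchanges hydroxy for chlorine, so the expectation is uncertain. The step is estimated as a number 38.5 percentage points lower from compound 2 to compound 3 (beyond the scatter), most likely downward. Compound 3 is expected to give 40%, in the range 10% to 80%.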

Compound 3, a percentage reported as inhibition, at one concentration (the size of the read-out at that concentration, not a potency): 35.2%
Beside the measured number, compound 3's estimate is 4.8 percentage points above it; the range from low to high includes it.
By their numbers in this assay, from the lowest: compound 1; then compound 3; then compound 2.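

In this assay, swapping the aryl group on the carbon between the two ring nitrogen atoms moves the read-out in both directions: 2-chlorophenyl gives a number 43.3 percentage points lower from compound 2 to compound 3 (beyond the scatter), yet also a number 18 percentage points higher from compound 1 to compound 3 (beyond the scatter). Compounds 1 and 2 both carry hydroxy and fall on either side of compound 3, which carries none, so among these three compounds the presence of hydroxy alone does not set the order. No supporting data on the reason for these differences are available.

The step to compound 3 removes the hydroxy and introduces chlorine at another ring position in a single change, so the contribution of each remains unresolved. Unsubstituted phenyl, 2-hydroxyphenyl and 3-chlorophenyl at this position would separate these contributions.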